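A few compounds are considered here, and "the series" means these few. Any claim that something is new, unique, unknown or untested is made for them only; others in the source may bear on it.

Measured so far in a functional assay on HL-60 cells (Homo sapiens) for cytotoxicity, read by MTT assay, with a stated time of 72 h; a lower number here means a stronger inhibitor, a higher number a weaker inhibitor:

Compound 1, `O=[N+]([O-])c1ccc(O)c(/C=N/Nc2nc3ccccc3s2)c1`: in this assay compound 1 gives 1650 nM.
Compound 2, `CN(C)c1ccc(/C=N/Nc2nc3ccccc3s2)cc1`: in this assay compound 2 reaches only a limit of the assay, > 16800 nM.
Compound 3, `O=C(O)c1ccccc1/C=N/Nc1nc2ccccc2s1`: in this assay compound 3 likewise reaches only a limit, > 16800 nM.

Compound 2 therefore stands not at a number but at the upper edge of what this assay reports, a position it shares with compound 3, as the limit of > 16800 nM in this assay, at which 2 of the 3 values shown sit, shows; only compound 1 gives a measured number. Among the compounds with values here, no pair of these three compounds differs in a single place, so no measured step is available to lean on.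

Compound 4, `Oc1ccc(/C=N/Nc2nc3ccccc3s2)cc1`, is still to be measured in this assay. Against compound 2 it carries hydroxy in place of dimethylamino on an aromatic carbon, that is, hydroxy in place of dimethylamino on an aromatic carbon. Compound 1 also bears a hydroxy group and gives a number, but it carries a nitro group as well, so it does not tell what the hydroxy alone would do.

Compound 4 is therefore expected to remain weak, with an estimate of 12000 nM and a range from 3000 nM to 40000 nM. The step this estimate implies, an at least 1.4-fold lower number from compound 2 to compound 4 (0.14 log units; that floor lies within the scatter), is expected to be small and may well not separate from the limit at all.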

Compound 4, half-maximal inhibitory concentration: 4600 nM
The estimate for compound 4 lay 2.6-fold (0.42 log units) above the measured number; the range from low to high includes it.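

On an aromatic carbon para to a large group, hydroxy in place of dimethylamino gives in this assay an at least 3.6-fold lower number from compound 2 to compound 4 (0.56 log units; beyond the scatter), which is the first change in a single place among these compounds to be read, and it lies beyond the scatter. It also shows that a hydroxy group at this place, with no nitro group on the ring, is enough to bring a compound off the limit and onto a measured number, something compound 1, which carries both groups, could not show. The step has only a floor and no full size, since compound 2 stands at a limit of the assay and not at a number: the limit of > 16800 nM in this assay, at which 2 of the 4 values shown sit.

The compounds shown leave open whether the lower number comes with the hydroxy group itself or simply with the loss of dimethylamino, a question that methoxy, a primary amine or a plain hydrogen at the same place would bear on. Also open, on these data alone, is whether hydroxy would give a similar step on another carbon of this ring, or whether a halogen such as fluorine or chlorine there would do the same.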